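Two Chlorines in Place of an Amine: Expecting Compound 3

A few compounds are considered here, and "the series" means these few. Any claim that something is new, unique, unknown or untested is made for them only; others in the source may bear on it.

Measured so far:
Compound 1 `COc1cc(-c2cc(/C=C/C(=O)c3ccc(N)cc3)[nH]n2)cc(OC)c1OC` gives 1370 nM
Compound 2 `COc1ccc(-c2cc(/C=C/C(=O)c3ccc(OC)c(OC)c3)[nH]n2)cc1` gives 1350 nM

Both numbers come from a functional assay on HCT-15 cells (Homo sapiens) for inhibition, read by sulforhodamine B assay, with a stated time of 48 h; on this read-out higher numbers stand for weaker inhibition of growth and lower numbers for stronger inhibition of growth. Compound 1 has the higher of the two numbers, yet its gap to compound 2 lies within the usual scatter, so the two cannot be told apart. Compound 3 `COc1cc(-c2cc(/C=C/C(=O)c3ccc(Cl)c(Cl)c3)[nH]n2)cc(OC)c1OC` differs from compound 1 in one place: 3,4-dichlorophenyl in place of 4-aminophenyl on a carbonyl carbon. Going by the values given here, no measured pair shows a change of this kind, so the size of the step is open. Compound 3 is expected to land close to compound 1, with a step of a 1.5-fold higher number from compound 1 to compound 3 (0.16 log units; within the scatter) that may stay within the scatter, perhaps leaning toward weaker inhibition. The estimate for compound 3 is 2000 nM, between 500 nM and 8000 nM.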

Compound 3, concentration for 50% growth inhibition: 4290 nM
For compound 3 the middle estimate is 2.1-fold (0.33 log units) below the measured one; the measured number falls inside the stated range.
By their numbers in this assay, from the lowest: compounds 2 and 1 (each within the scatter of the next); then compound 3.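

In this assay the group on the carbonyl carbon matters: 3,4-dichlorophenyl in place of 4-aminophenyl gives a 3.1-fold higher number from compound 1 to compound 3 (0.50 log units; beyond the scatter) and so a modest but real weakening of growth inhibition. The change replaces a ring carrying one hydrogen-bond donor and one acceptor with a ring carrying neither. Nothing available explains the weakening.

Going by these compounds, removing the amine and adding the two chlorines happen in a single change, so their separate contributions remain open. On these data alone, whether 4-chlorophenyl or 4-hydroxyphenyl on this carbon would sit closer to compound 1 or compound 3 also remains open.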